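The source may hold more compounds than are shown below. What is called first, only, known or untested is meant among the compounds shown, and "the series" means these compounds.

Series notes, with all readings taken from a functional assay on HeLa cells (Homo sapiens) for antiproliferative activity, read by MTT assay, with a stated time of 24 h (a lower number here means a stronger inhibitor, a higher number a weaker inhibitor), and no other test. Compound 1 `Sc1nnc(-c2ccc3c(c2)OCCO3)n1-c1ccccc1` carries hydrogen on the sulfur and gives 51900 nM as its reading. Compound 2 `Cc1ccccc1CSc1nnc(-c2ccc3c(c2)OCCO3)n1-c1ccccc1` gives 36000 nM as its reading, and compound 3 `Fc1ccc(CSc2nnc(-c3ccc4c(c3)OCCO4)n2-c2ccccc2)cc1` gives 46900 nM on the same scale. Compound 2 therefore stands level with the other two: its gaps to both lie within the scatter, and no order can be read among the three.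

The next entry is compound 4 `Brc1cccc(CSc2nnc(-c3ccc4c(c3)OCCO4)n2-c2ccccc2)c1`, with 3-bromophenyl in place of 2-methylphenyl on a saturated chain carbon bound to a sulfur as the whole difference.

For the measured compounds named here, three measured steps bear on this. Replacing the hydrogen on the sulfur gave a 1.4-fold lower number from compound 1 to compound 2 (0.16 log units; within the scatter) in one case and a 1.1-fold lower number from compound 1 to compound 3 (0.04 log units; within the scatter) in the other. Going by the values given here, the closest precedent, a swap of the phenyl group on that same carbon, is a 1.3-fold higher number from compound 2 to compound 3 (0.11 log units; within the scatter) and also stays small. Among the compounds with values here, no bromine-bearing compound has been measured yet, so this rests on three compounds only. No step beyond the scatter is expected in this assay and no direction can be assigned. The expected change is a 1.1-fold higher number from compound 2 to compound 4 (0.02 log units; within the scatter) and would stay inside the scatter. For compound 4 the estimated value is 38000 nM with an expected range from 14000 nM to 75000 nM as the working figures.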

Compound 4, half-maximal inhibitory concentration: 44200 nM
For compound 4 the middle estimate is 1.2-fold (0.07 log units) below the measured one; the measured number falls inside the stated range.
By their numbers in this assay, from the lowest: compounds 2, 4, 3 and 1 (each within the scatter of the next).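

In this assay, 3-bromophenyl on a saturated chain carbon bound to a sulfur extends the tolerated groups at this place to a bromine-bearing ring, with a 1.2-fold higher number from compound 2 to compound 4 (0.09 log units; within the scatter) and a 1.1-fold lower number from compound 3 to compound 4 (0.03 log units; within the scatter) showing no separation from either earlier aryl group. The step from hydrogen on the sulfur is also flat for this third benzyl group, at a 1.2-fold lower number from compound 1 to compound 4 (0.07 log units; within the scatter), so compounds 1 to 4 show no measurable response to any of the changes made at this sulfur. No measurement of any property of these groups bears on this flat result, and none accounts for it.

The compounds shown leave open whether any group on this sulfur can move the reading beyond the scatter, since every substituent so far is either hydrogen or a substituted benzyl group; a carboxylic acid, a tertiary amine or a longer alkyl chain ending in a hydroxyl group would test this. They also leave open whether changes elsewhere, such as replacing the phenyl group on the shared core with a pyridine, would do more than changes at this sulfur.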